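This account rests on a few compounds, and the source may have more. Where it says the series, first, only, none or still open, it means among the compounds named here.

Compound 1 `COc1ccc(C(=O)/C=C/c2ccc(F)cc2)c2c1C=CC(C)(C)O2` carries a 4-fluorophenyl group on the double-bonded chain attached to the shared core. In a functional assay on HT-29 cells (Homo sapiens) for antiproliferative activity, read by MTT assay, with a stated time of 24 h (a higher number here means a weaker inhibitor, a lower number a stronger inhibitor), compound 1 reaches only the limit > 10000 nM, which is not a number but the edge of what this assay reports. Its two neighbours are the same: compound 2 `COc1ccc(C(=O)/C=C/c2ccc(-n3ccnc3)cc2)c2c1C=CC(C)(C)O2` stops at the limit > 6600 nM. Compound 3 `COc1ccc(C(=O)/C=C/c2ccc(C(F)(F)F)cc2)c2c1C=CC(C)(C)O2` stops at the limit > 10000 nM. The steps a step that the two limits leave unreadable from compound 1 to compound 2, a step that the two limits leave unreadable from compound 1 to compound 3 and a step that the two limits leave unreadable from compound 2 to compound 3 therefore carry no readable size. Compound 4 `COc1ccc(C(=O)/C=C/c2ccco2)c2c1C=CC(C)(C)O2` differs from compound 1 by furan-2-yl in place of 4-fluorophenyl on a double-bonded chain carbon bound to a double-bonded chain carbon. Among the measured compounds shown here, no measured step bears on this exchange, so the expectation for compound 4 rests only on the fact that every compound shown sits at a limit of > 10000 nM in this assay, at which 2 of the 3 values shown sit (the limit of > 6600 nM in this assay, at which 1 of the 3 values shown sits). Compound 4 is therefore expected near 15000 nM, within 5000 nM to 50000 nM, meaning an estimated step that the limit leaves unreadable from compound 1 to compound 4.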

Compound 4, half-maximal inhibitory concentration: > 10000 nM
Compound 4 gave a limit, no number (the forecaster's own chance of this, stated with the estimate: 75%); the middle value is on the limit's open side.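

Compound 4 stops at the limit > 10000 nM, which is not a number. Compound 1 also sits at a limit, so no size can be read for the exchange between them. The compounds shown leave open whether furan-2-yl or 4-fluorophenyl gives the stronger inhibitor in this assay, and what the true potency of any of them is.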